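Cytotoxicity notes: dimethylamino in place of nitro

This account rests on a few compounds, and the source may have more. Where it says the series, first, only, none or still open, it means among the compounds named here.

In an ADME assay on L6 cells (Rattus norvegicus) for cytotoxicity, read by resazurin assay, with a stated time of 72 h (a higher number here means a weaker inhibitor, a lower number a stronger inhibitor), compound 1 (`CC(C)c1ccc(C(=O)NC(=O)c2ccccc2O)cc1`) gives 19 ug/mL and compound 2 (`O=C(NC(=O)c1ccccc1O)c1ccc(OC(F)(F)F)cc1`) gives 84 ug/mL in the same read-out. Compound 3 (`O=C(NC(=O)c1ccccc1O)c1ccc([N+](=O)[O-])cc1`) gives 53 ug/mL there. Two steps lead to this value: a 1.6-fold lower number from compound 2 to compound 3 (0.20 log units; within the scatter) and a 2.8-fold higher number from compound 1 to compound 3 (0.45 log units; beyond the scatter).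

Compound 4 (`CN(C)c1ccc(C(=O)NC(=O)c2ccccc2O)cc1`) differs from compound 3 at one place (dimethylamino in place of nitro on an aromatic carbon): dimethylamino in place of nitro on an aromatic carbon, para to a large group. The nearest evidence is the pair of modest steps away from the isopropyl compound, a 2.8-fold higher number from compound 1 to compound 3 (0.45 log units; beyond the scatter) and a 4.4-fold higher number from compound 1 to compound 2 (0.65 log units; beyond the scatter) in this assay. Dimethylamino itself has no measured precedent, but like isopropyl it carries no oxygen, so compound 4 is expected to move part of the way back toward compound 1 (19 ug/mL). The expected change is small, toward a lower number: a 1.8-fold lower number from compound 3 to compound 4 (0.25 log units; within the scatter) as estimated. For compound 4 the estimated value is 30 ug/mL with an expected range from 11 ug/mL to 80 ug/mL in this assay.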

Compound 4, half-maximal inhibitory concentration: 54 ug/mL
For compound 4 the middle estimate is 1.8-fold (0.26 log units) below the measured one; the range from low to high includes it.
By their numbers in this assay, from the lowest: compound 1; then compounds 3, 4 and 2 (each within the scatter of the next).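

In this assay, dimethylamino and nitro on this aromatic carbon, para to a large group, cannot be told apart (a 1.0-fold higher number from compound 3 to compound 4 (0.01 log units; within the scatter)), and the same holds for dimethylamino and trifluoromethoxy (a 1.6-fold lower number from compound 2 to compound 4 (0.19 log units; within the scatter)). Dimethylamino carries no oxygen, yet only isopropyl stands apart (a 2.8-fold higher number from compound 1 to compound 4 (0.45 log units; beyond the scatter)), so the presence of oxygen in the group does not sort these four compounds, with compound 4 as the case against that split. Nothing at hand accounts for the isopropyl compound's separate position.

From the compounds shown here alone, it remains open whether the lower number belongs to isopropyl alone or extends to other carbon-only groups such as tert-butyl or a longer chain. A carboxylic acid or a primary amine at this place also remains an open case.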